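Replacing Bromo with Hydroxy in Compound 3

This account rests on a few compounds, and the source may have more. Where it says the series, first, only, none or still open, it means among the compounds named here.

In a functional assay on MGC-803 cells (Homo sapiens) for inhibition, read by CCK-8 assay, with a stated time of 48 h (a higher number here means a weaker inhibitor, a lower number a stronger inhibitor), compound 1 `COc1cc(N(Cc2ccc(Br)cc2)C(=O)CSC(=S)N2CCN(C(=O)OC(C)(C)C)CC2)cc(OC)c1OC` gives 12400 nM, compound 2 `COc1ccc(CN(C(=O)CSC(=S)N2CCN(C(=O)OC(C)(C)C)CC2)c2cc(OC)c(OC)c(OC)c2)cc1F` gives 4870 nM and compound 3 `COc1ccc(CN(C(=O)CSC(=S)N2CCN(C(=O)OC(C)(C)C)CC2)c2cc(OC)c(OC)c(OC)c2)cc1Br` gives 3710 nM. Compound 3 stands level with compound 2, as a 1.3-fold lower number from compound 2 to compound 3 (0.12 log units; within the scatter) stays within the scatter, and clear of compound 1, as a 3.3-fold lower number from compound 1 to compound 3 (0.52 log units; beyond the scatter) goes beyond it. Compound 4 `COc1ccc(CN(C(=O)CSC(=S)N2CCN(C(=O)OC(C)(C)C)CC2)c2cc(OC)c(OC)c(OC)c2)cc1O` differs from compound 3 by hydroxy in place of bromo on an aromatic carbon, with hydroxy in place of bromo on an aromatic carbon. The closest evidence is a 1.3-fold lower number from compound 2 to compound 3 (0.12 log units; within the scatter), a swap on that same carbon, while a 2.5-fold lower number from compound 1 to compound 2 (0.41 log units; beyond the scatter) is a modest step with a larger change. Within the data shown here, no measured compound carries hydroxy, so no step beyond the scatter is expected in this assay, though uncertainty is wide. The expected change is a 1.2-fold lower number from compound 3 to compound 4 (0.09 log units; within the scatter). For compound 4 the estimated value is 3000 nM, within a range of 900 nM to 9000 nM.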

Compound 4, half-maximal inhibitory concentration: 82 nM
The estimate for compound 4 lay 37-fold (1.56 log units) above the measured number; the measured number lies below the stated range.
By their numbers in this assay, from the lowest: compound 4; then compounds 3 and 2 (each within the scatter of the next); then compound 1.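

In this assay this assay, the position proves far more sensitive than the fluoro and bromo compounds, which sit within the scatter of each other, had suggested. Hydroxy in place of bromo gives a large step (a 45-fold lower number from compound 3 to compound 4 (1.66 log units; beyond the scatter)), and hydroxy in place of fluoro gives one of similar scale (a 59-fold lower number from compound 2 to compound 4 (1.77 log units; beyond the scatter)), while the whole 3-hydroxy-4-methoxyphenyl group in place of 4-bromophenyl gives the largest (a 150-fold lower number from compound 1 to compound 4 (2.18 log units; beyond the scatter)). Nothing available accounts for this gain.

As far as these compounds go, whether an amine or a carboxylic acid on this aromatic carbon would keep the gain remains open. So does whether hydroxy would keep it without the methoxy group it sits ortho to.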